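The source may report more compounds than this note shows. Statements on the series, on what has been measured and on what is new or still open speak of the compounds shown alone.

In an ADME assay on L1210 cells (Mus musculus) for cytotoxicity, with a stated time of 48 h; on this read-out lower numbers stand for stronger inhibition and higher numbers for weaker inhibition:
- compound 1 `CC1=CCC[C@](C)(CC/C(C)=C/CC2=C(O)C(=O)C=C(N[C@@H](CO)C(=O)O)C2=O)[C@@H]1C`: > 10 ug/mL, a limit of the assay
- compound 2 `CC1=CCC[C@](C)(CC/C(C)=C/CC2=C(O)C(=O)C=C(N[C@H](C(=O)O)C(C)C)C2=O)[C@@H]1C`: 3.4 ug/mL

For the measured compounds named here, compound 2, at 3.4 ug/mL, holds the only true number so far. Compound 3 `CC1=CCC[C@](C)(CC/C(C)=C/CC2=C(O)C(=O)C=C(N[C@@H](C(=O)O)[C@H](C)O)C2=O)[C@@H]1C` differs from it by 1-carboxy-2-hydroxypropyl in place of 1-carboxy-2-methylpropyl on an amine nitrogen. Going by the values given here, one measured step bears on this change: an at least 2.9-fold lower number from compound 1 to compound 2 (0.46 log units; beyond the scatter), where isopropyl replaced hydroxymethyl. Compound 3 brings a hydroxy group back into that side chain, so that step suggests a reversal, though a single pair is thin support. The expected change is a 2.4-fold higher number from compound 2 to compound 3 (0.37 log units; beyond the scatter), towards weaker inhibition in this assay. For compound 3 the estimated value is 8 ug/mL, with an expected range of 3.5 ug/mL to 20 ug/mL.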

Compound 3, half-maximal inhibitory concentration: > 10 ug/mL
Compound 3 ended at the assay's limit; the forecaster's own chance of this, stated with the estimate: 40%; middle value at least 1.2-fold (0.09 log units) away from the limit.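

Putting 1-carboxy-2-hydroxypropyl in place of 1-carboxy-2-methylpropyl on the amine nitrogen gives an at least 2.9-fold higher number from compound 2 to compound 3 (0.46 log units; beyond the scatter) in this assay. The earlier loss with a hydroxy-bearing side chain therefore appears on a second chain, and here the hydroxy group takes the place of a methyl group on the same branched chain. The step between compound 1 and compound 3 cannot be read, since each value is a limit rather than a number: the limit of > 10 ug/mL in this assay, at which 2 of the 3 values shown sit.

From the compounds shown here alone, it remains open whether a longer hydrocarbon chain or an amine on this side chain would give a lower number than compound 2.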